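A few compounds are considered here, and "the series" means these few. Any claim that something is new, unique, unknown or untested is made for them only; others in the source may bear on it.

Measured compounds:

Compound 1 `Cc1ccc(-n2nccn2)c(C(=O)N2CC3(CC3)C[C@H]2CNc2ccc(Cl)cn2)c1` — in a functional assay on HEK293 cells for antagonist activity at Orexin receptor type 2 (Homo sapiens), read by FLIPR and calcium flux (a lower number here means a less potent compound, a higher number a more potent compound, by a factor of ten per unit of this negative logarithm), compound 1 gives a limit of < 5.
Compound 2 `Cc1ccc(-n2nccn2)c(C(=O)N2CCC3(CC3)C[C@H]2CNc2cccc(C)n2)c1` — in this assay compound 2 gives a limit of < 5.
Compound 3 `Cc1ccc(-n2nccn2)c(C(=O)N2CCC3(CC3)C[C@H]2CNc2ccc(Cl)cn2)c1` — in this assay compound 3 gives a limit of < 5.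

All three values are limits of the assay and not numbers; this is recorded as the limit of < 5 in this assay, at which 3 of the 3 values shown sit. Compound 1 therefore stands only at a limit, and the two further values shown are also limits.

Compound 3 and compound 2 differ in one place: 6-methylpyridin-2-yl in place of 5-chloropyridin-2-yl on an amine nitrogen. The step that the two limits leave unreadable from compound 3 to compound 2 cannot be read, as both ends sit at a limit. The difference between the core of compound 1 and the core of compound 3 is not broken down here.

Compound 4 `Cc1ccc(-n2nccn2)c(C(=O)N2CC3(CC3)C[C@H]2CNc2cccc(C)n2)c1` is not yet measured in this assay. It differs from compound 1 by 6-methylpyridin-2-yl in place of 5-chloropyridin-2-yl on an amine nitrogen, the same change as from compound 3 to compound 2, and the place is the same word for word. For the measured compounds named here, since the earlier step is unreadable, its size gives no guide; the expectation rests on the limit recorded for compound 1, < 5, and on the fact that every value so far sits at that limit. The step from compound 1 to compound 4 is expected to be a step that the limit leaves unreadable from compound 1 to compound 4, with most likely another limit. Compound 4 is estimated at 4.6, between 4 and 5.3.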

Compound 4, negative logarithm of the antagonist equilibrium constant: < 5
Compound 4 was reported as a limit; the forecaster's own chance of this, stated with the estimate: 80%; the middle value is on the limit's open side.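

In this assay compound 4 gives < 5, a limit of the assay and not a number. For the compounds shown here, neither the step from compound 1 to compound 4 nor the one from compound 3 to compound 2 can be read, as each pair has a limit at both ends: the limit of < 5 in this assay, at which 4 of the 4 values shown sit. The compounds shown leave open how potent any of them is, and whether 6-methylpyridin-2-yl and 5-chloropyridin-2-yl differ at all on the core of compound 1 or the core of compound 3.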